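The source may report more compounds than this note shows. Statements on the series, on what has been measured and on what is new or still open speak of the compounds shown alone.

Compound 1 `Nc1ncnc2c1ccn2-c1ccc(NC(=O)Nc2cc(C(F)(F)F)cc(C(F)(F)F)c2)cc1` serves as the reference of the series; in an ADME assay on HS27 cells (Homo sapiens) for antiproliferative activity, read by MTT assay, with a stated time of 24 h (a higher number here means a weaker inhibitor, a lower number a stronger inhibitor), compound 1 gives 9500 nM. Compound 2 `O=C(Nc1ccc(-n2ccc3c(NC(=O)c4ccccc4)ncnc32)cc1)Nc1cc(C(F)(F)F)cc(C(F)(F)F)c1` reaches only the limit of this assay, > 10000 nM, which is a limit and not a number. Within the data shown here, the change from compound 1 to compound 2 is benzoyl in place of hydrogen on a nitrogen on an aromatic ring, and the step it made is an at least 1.0-fold higher number from compound 1 to compound 2 (0.02 log units; that floor lies within the scatter), the sole evidence on it being (the limit of > 10000 nM in this assay, at which 1 of the 3 values shown sits). Compound 3 `Nc1ncnc2c1ccn2-c1ccc(NC(=O)c2cccc(C(F)(F)F)c2)cc1` carries a different core; in this assay compound 3 gives 7100 nM, and the difference between the cores of compound 1 and compound 3 is not broken down here. Compound 4 `O=C(Nc1ccc(-n2ccc3c(NC(=O)c4ccccc4)ncnc32)cc1)c1cccc(C(F)(F)F)c1` is not yet measured; it differs from compound 3 by benzoyl in place of hydrogen on a nitrogen on an aromatic ring, the same change, at a place described in the same words. The step from compound 3 to compound 4 is expected to be a 1.3-fold higher number from compound 3 to compound 4 (0.13 log units; within the scatter), resting on the earlier step from compound 1 to compound 2. Compound 4 is expected to give 9500 nM, between 5000 nM and 20000 nM, with a fair chance that only a limit is reported.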

Compound 4, half-maximal inhibitory concentration: 5900 nM
The estimate for compound 4 lay 1.6-fold (0.21 log units) above the measured number; measured number inside the range.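

In this assay, benzoyl in place of hydrogen on the nitrogen gives a 1.2-fold lower number from compound 3 to compound 4 (0.08 log units; within the scatter), so on the core of compound 3 the change makes no difference that can be told from the scatter. Set beside the earlier step, this does not settle whether the change carries over from one core to the other: the same change on two cores in this assay, an at least 1.0-fold higher number (0.02 log units; that floor lies within the scatter) from compound 1 to compound 2 and a 1.2-fold lower number (0.08 log units; within the scatter) from compound 3 to compound 4; the limit leaves it open whether they differ Compound 2 is known only through a limit, > 10000 nM, and the size of the step on the core of compound 1 stays unknown.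

The compounds shown leave open how a smaller acyl group such as acetyl, or a benzoyl ring bearing a carboxylic acid or an amine, would behave on that nitrogen. From the compounds shown here alone, whether any such group would give a step beyond the scatter also remains open.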